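The source may report more compounds than this note shows. Statements on the series, on what has been measured and on what is new or still open speak of the compounds shown alone.

Compound 1 (`Cc1ccccc1Nc1nc(Nc2ccc(N3CCN(C(=O)OC(C)(C)C)CC3)cc2)ncc1Cl`): 2250 nM
Compound 2 (`CN1CCN(c2ccc(Nc3ncc(Cl)c(Nc4ccccc4)n3)nc2)CC1`): 51800 nM

In a functional assay on MCF7 cells (Homo sapiens) for inhibition, read by CCK-8 assay, with a stated time of 48 h (a higher number here means a weaker inhibitor of growth, a lower number a stronger inhibitor of growth), compound 2 stands highest of the two, at 51800 nM, beyond the scatter from compound 1. Compound 3 (`CN1CCN(c2ccc(Nc3ncc(Cl)c(NCc4ccc(F)cc4)n3)nc2)CC1`) carries 4-fluorobenzyl in place of phenyl on a nitrogen on an aromatic ring. Among the measured compounds shown here, no two measured compounds differ in one place only, so nothing measured sizes this change. A small step towards a lower number in this assay is expected, perhaps none beyond the scatter. The expected step is a 1.7-fold lower number from compound 2 to compound 3 (0.24 log units; within the scatter). The estimate for compound 3 is 30000 nM, with an expected range of 9000 nM to 90000 nM.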

Compound 3, concentration for 50% growth inhibition: 19300 nM
The estimate for compound 3 lay 1.6-fold (0.19 log units) above the measured number, and the stated range covers the measured number.
By their numbers in this assay, from the lowest: compound 1; then compound 3; then compound 2.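

In this assay, among the compounds shown here, this is the first step that can be read at this position: 4-fluorobenzyl in place of phenyl on a nitrogen on an aromatic ring gives a 2.7-fold lower number from compound 2 to compound 3 (0.43 log units; beyond the scatter). The position therefore accepts the larger group, and the step is modest, with compound 3 still at 19300 nM. Nothing shown accounts for the step. On these data alone, it remains open whether the step belongs to the extra carbon or to the fluorine, which plain benzyl on the same nitrogen would separate. As far as these compounds go, whether a 2-phenylethyl or cyclohexyl group there would extend the step also remains open.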